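Removing the hydrazone arm: compound 4 as a bare amine

The source may report more compounds than this note shows. Statements on the series, on what has been measured and on what is new or still open speak of the compounds shown alone.

Of the compounds shown here, three sharing one core have been tested in a functional assay on MCF7 cells (Homo sapiens) for inhibition, read by MTT assay, with a stated time of 48 h; on this read-out higher numbers stand for weaker inhibition and lower numbers for stronger inhibition. Compound 1, `CCOC(=O)C1=C(N/C=N/c2cccnc2Cl)Nc2[nH]nc(C)c2C1c1ccc(N(C)C)cc1`, gives 4180 nM. Compound 2, `CCOC(=O)C1=C(N/N=C(/C#N)C(=O)OCC)Nc2[nH]nc(C)c2C1c1ccc(N(C)C)cc1`, gives 35600 nM. Compound 3, `CCOC(=O)C1=C(NN=C(C#N)C#N)Nc2[nH]nc(C)c2C1c1ccc(N(C)C)cc1`, gives 12100 nM, which places it second highest of the three: the change from compound 1 to compound 3 shows a 2.9-fold higher number from compound 1 to compound 3 (0.46 log units; beyond the scatter), while the change from compound 2 to compound 3 shows a 2.9-fold lower number from compound 2 to compound 3 (0.47 log units; beyond the scatter). Compound 4, `CCOC(=O)C1=C(N)Nc2[nH]nc(C)c2C1c1ccc(N(C)C)cc1`, has not yet been measured in this assay . Its difference from compound 3 is a hydrogen atom in place of a group of 6 heavy atoms (3 carbon, 3 nitrogen; no ring), on an amine nitrogen.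

Among the measured compounds shown here, no measured step removes the whole substituent on that amine nitrogen; all three, including an 8.5-fold higher number from compound 1 to compound 2 (0.93 log units; beyond the scatter), exchange one group for another. Those exchanges were modest yet beyond the scatter, so the nitrogen substituent does matter to the number, and the smallest of the three groups in compound 3 gave a number between the two larger ones rather than the lowest. Stripping the group away entirely is therefore expected to push the number upward, probably by a modest amount, with considerable uncertainty. Compound 4 is estimated at 25000 nM, within a range from 8000 nM to 80000 nM, meaning an expected step of a 2.1-fold higher number from compound 3 to compound 4 (0.32 log units; beyond the scatter).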

Compound 4, half-maximal inhibitory concentration: 5060 nM
Beside the measured number, compound 4's estimate is 4.9-fold (0.69 log units) above it; measured number below the stated range.
By their numbers in this assay, from the lowest: compounds 1 and 4 (each within the scatter of the next); then compound 3; then compound 2.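

In this assay, compound 4 gives the first view of this amine nitrogen with only a hydrogen on it, and that hydrogen gives a 2.4-fold lower number from compound 3 to compound 4 (0.38 log units; beyond the scatter) and a 7.0-fold lower number from compound 2 to compound 4 (0.85 log units; beyond the scatter). The two open-chain groups of compound 2 and compound 3 are therefore not needed to reach the number seen with the bare amine, and both sit on the weaker side of it. The group carrying a six-membered aromatic ring behaves differently, with a 1.2-fold higher number from compound 1 to compound 4 (0.08 log units; within the scatter), so among these four compounds no group on this nitrogen gives a number beyond the scatter below that of the bare amine, and compound 1 is the one case where a group leaves the number effectively unchanged.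

Whether a smaller group, such as a methyl or an acetyl, would bring the number lower than the bare amine does, or would raise it as the open-chain groups do, cannot be told from these compounds. The data shown offer no evidence on the reason for the size of these steps.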